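The source may hold more compounds than are shown below. What is called first, only, known or untested is meant among the compounds shown, and "the series" means these compounds.

Measured so far in an ADME assay on RAW264.7 cells (Mus musculus) for cytotoxicity, read by MTT assay; a lower number here means a stronger inhibitor, a higher number a weaker inhibitor:
- compound 1 `CCCCCCCCCCOc1cccc(O)c1C(=O)/C=C/c1ccc(O)c(Cl)c1`: > 30000 nM
- compound 2 `CCCCCCCCCCOc1cccc(O)c1C(=O)/C=C/c1cc(OC)c(O)c(OC)c1`: > 30000 nM
- compound 3 `CCCCCCCCCCOc1cccc(O)c1C(=O)/C=C/c1ccccc1O`: > 30000 nM

All three entries are limits of the assay, not numbers. Compound 3 has only a limit, > 30000 nM. The same holds across the series: the limit of > 30000 nM in this assay, at which 3 of the 3 values shown sit.

Compound 4 `CCCCCCCCCCOc1cccc(O)c1C(=O)/C=C/c1ccc(C)cc1` has not yet been measured. It differs from compound 3 in a single place, with 4-methylphenyl in place of 2-hydroxyphenyl on a double-bonded chain carbon bound to a double-bonded chain carbon.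

Among the compounds with values here, three measured steps bear on this change. Each swaps the group at that same place. They are a step that the two limits leave unreadable from compound 1 to compound 2, a step that the two limits leave unreadable from compound 1 to compound 3 and a step that the two limits leave unreadable from compound 2 to compound 3. None of them has a size that can be read, so they give no direction for the new group. The 4-methylphenyl group itself has not been tested in this series, which leaves some uncertainty. The expectation is therefore no step beyond the scatter in this assay, and most likely another result reported only as a limit.

The estimated change is a step that the limit leaves unreadable from compound 3 to compound 4. For compound 4 the expected value is 40000 nM, with an estimated range of 15000 nM to 100000 nM.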

Compound 4, half-maximal inhibitory concentration: > 30000 nM
Compound 4 ended at the assay's limit; the forecaster's own chance of this, stated with the estimate: 85%; the middle value does not contradict the limit.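

In this assay compound 4 gives > 30000 nM, which is a limit of the assay and not a number. Its steps from compound 1, compound 2 and compound 3 cannot be read, and all four compounds share one result: the limit of > 30000 nM in this assay, at which 4 of the 4 values shown sit. The compounds shown leave open whether changing the group at this place alters the true value in this assay at all.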